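Swapping Nitro for Fluoro: What Cytotoxicity to Expect

A few compounds are considered here, and "the series" means these few. Any claim that something is new, unique, unknown or untested is made for them only; others in the source may bear on it.

Compound 1 `CC(C)(C)[C@H]1C(O)=C(C2=CS(=O)(=O)c3cc([N+](=O)[O-])ccc3N2)C(=O)N1Cc1ccc(F)cc1`: > 50000 nM
Compound 2 `CC(C)(C)[C@H]1C(O)=C(C2=CS(=O)(=O)c3cc(NS(C)(=O)=O)cc(F)c3N2)C(=O)N1Cc1ccc(F)cc1`: > 50000 nM

In an ADME assay on 2209-23 cells (Homo sapiens) for cytotoxicity, read by WST assay and thymidine incorporation (a lower number here means that less compound is tolerated, a higher number that more compound is tolerated), compound 1 reaches only a limit of the assay, > 50000 nM. Compound 2 likewise sits at a limit in this assay, > 50000 nM. Both measured values rest at the limit of > 50000 nM in this assay, at which 2 of the 2 values shown sit, so compound 1 can be placed no further than that. Compound 3 `CC(C)(C)[C@H]1C(O)=C(C2=CS(=O)(=O)c3cc(F)ccc3N2)C(=O)N1Cc1ccc(F)cc1` has not yet been measured. It differs from compound 1 by fluoro in place of nitro on an aromatic carbon. For the measured compounds named here, no step between measured compounds is known, and the change from compound 1 to compound 3 is expected to amount to a step that the limit leaves unreadable from compound 1 to compound 3, nothing beyond the scatter. Compound 3 is estimated at 60000 nM in this assay, within 25000 nM to 150000 nM, most likely reported again as a limit.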

Compound 3, half-maximal cytotoxic concentration: > 50000 nM
Compound 3 ended at the assay's limit (the forecaster's own chance of this, stated with the estimate: 85%); the middle value is on the limit's open side.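

Fluoro in place of nitro gives no readable step between compound 1 and compound 3 in this assay: the limit of > 50000 nM in this assay, at which 3 of the 3 values shown sit. The compounds shown leave open where the half-maximal cytotoxic concentration of compound 1, compound 2 or compound 3 actually lies, and whether they differ at all.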